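A few compounds are considered here, and "the series" means these few. Any claim that something is new, unique, unknown or untested is made for them only; others in the source may bear on it.

Compound 1 `CCn1c(C(=O)N[C@@H](C)CO)ccc1C(CC)(CC)c1ccc(OCS(=O)(=O)c2ccccc2)c(C)c1` gives 15300 nM in a functional assay on BXPC-3 cells (Homo sapiens) for antiproliferative activity, read by MTT assay, with a stated time of 24 h; a higher number here means a weaker inhibitor, a lower number a stronger inhibitor.
Compound 2 `CCn1c(C(=O)NCCO)ccc1C(CC)(CC)c1ccc(OCS(=O)(=O)c2ccccc2)c(C)c1` gives 19900 nM.
Compound 3 `CCn1c(C(=O)NCCCO)ccc1C(CC)(CC)c1ccc(OCS(=O)(=O)c2ccccc2)c(C)c1` gives 26600 nM.

The three compounds share one core and differ only in the group on the amide-type nitrogen. Compound 3 is not set apart from either partner: the step of a 1.7-fold higher number from compound 1 to compound 3 (0.24 log units; within the scatter) and the step of a 1.3-fold higher number from compound 2 to compound 3 (0.13 log units; within the scatter) both lie within the scatter, as does a 1.3-fold higher number from compound 1 to compound 2 (0.11 log units; within the scatter), so no order among the three can be claimed. Compound 4 `CCn1c(C(=O)N[C@@H](C(=O)O)C(C)C)ccc1C(CC)(CC)c1ccc(OCS(=O)(=O)c2ccccc2)c(C)c1` continues this series: 1-carboxy-2-methylpropyl in place of 3-hydroxypropyl on an amide-type nitrogen. Within the data shown here, the steps that bear on this change are the same three, and none of them moved the number beyond the scatter. Compound 4 is therefore expected to give a number near that of compound 3, with the step of a 1.1-fold lower number from compound 3 to compound 4 (0.03 log units; within the scatter) estimated to stay within the scatter. The estimate for compound 4 is 25000 nM, in a range from 8000 nM to 80000 nM.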

Compound 4, half-maximal inhibitory concentration: 13900 nM
For compound 4 the middle estimate is 1.8-fold (0.25 log units) above the measured one, and the stated range covers the measured number.
By their numbers in this assay, from the lowest: compounds 4, 1, 2 and 3 (each within the scatter of the next).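

In this assay, 1-carboxy-2-methylpropyl on the amide-type nitrogen stays within the scatter of all three hydroxy-bearing groups: a 1.9-fold lower number from compound 3 to compound 4 (0.28 log units; within the scatter), a 1.4-fold lower number from compound 2 to compound 4 (0.16 log units; within the scatter) and a 1.1-fold lower number from compound 1 to compound 4 (0.04 log units; within the scatter). This position therefore accepts a carboxylic acid as well as an alcohol on the chain, and no order among the four compounds can be claimed. Nothing available gives a reason for this result. On these data alone, it remains open whether an amine, a ring or a much longer chain on this nitrogen would move the number beyond the scatter. As far as these compounds go, the opposite configuration of the 1-carboxy-2-methylpropyl stereocentre also remains open.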